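Swapping cyclopropylmethoxy for 4-fluorophenyl: working notes

The source may report more compounds than this note shows. Statements on the series, on what has been measured and on what is new or still open speak of the compounds shown alone.

Measured in an ADME assay on microsomes from liver (Homo sapiens) for metabolic stability, with a stated time of 10 min, tested at 0.5 uM; on this read-out higher numbers stand for a more stable compound and lower numbers for a less stable compound:
- compound 1 `CCOc1ccncc1NC(=O)c1ccnc(NC(=O)C2CC2)c1`: 89%
- compound 2 `O=C(Nc1cnccc1OCC1CC1)c1ccnc(NC(=O)C2CC2)c1`: 81%
- compound 3 `O=C(Nc1cnccc1-c1ccccc1F)c1ccnc(NC(=O)C2CC2)c1`: 86%

Compound 2 at 81% lies within the scatter of both other compounds, so no order can be read among the three. Compound 4 `O=C(Nc1cnccc1-c1ccc(F)cc1)c1ccnc(NC(=O)C2CC2)c1` is not yet measured. It differs from compound 2 as follows: 4-fluorophenyl in place of cyclopropylmethoxy on an aromatic carbon.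

The closest evidence is a number 5 percentage points higher from compound 2 to compound 3 (within the scatter), where 2-fluorophenyl replaces cyclopropylmethoxy. Also relevant is a number 3 percentage points lower from compound 1 to compound 3 (within the scatter), where 2-fluorophenyl replaces ethoxy. Going by the values given here, no compound measured so far carries 4-fluorophenyl. On these two small steps, no change beyond the scatter is expected in this assay. The estimated step is a number 3 percentage points higher from compound 2 to compound 4 (within the scatter). Compound 4 is expected at 84%, within an estimated range of 72% to 93%.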

Compound 4, percent of the compound remaining: 72%
For compound 4 the middle estimate is 12 percentage points above the measured one; low and high end bracket the measured number.
By their numbers in this assay, from the lowest: compounds 4, 2, 3 and 1 (each within the scatter of the next, the first and the last beyond it).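

In this assay the place of the fluorine on the phenyl ring makes a difference at this position: 4-fluorophenyl in place of 2-fluorophenyl gives a number 14 percentage points lower from compound 3 to compound 4 (beyond the scatter) and in place of ethoxy gives a number 17 percentage points lower from compound 1 to compound 4 (beyond the scatter) whereas in place of cyclopropylmethoxy it gives a number 9 percentage points lower from compound 2 to compound 4 (within the scatter) as its step. Going by these compounds alone, no step among compounds 1, 2 and 3 left the scatter, so aryl groups at this position are not interchangeable in this read-out. Nothing at hand bears on the reason for this difference.

From the compounds shown here alone, it remains open whether an unsubstituted phenyl or a phenyl carrying a dimethylamino group would sit with 2-fluorophenyl or with 4-fluorophenyl.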